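The source may report more compounds than this note shows. Statements on the series, on what has been measured and on what is new or still open speak of the compounds shown alone.

Compound 3 `O=c1c(Cn2ccnc2)coc2cc(F)ccc12` carries a 1H-imidazol-1-yl group on its side chain, and in an assay on V79MZh cells for inhibition of cytochrome P450 11B1, mitochondrial (Homo sapiens), with a stated time of 6 h (on this read-out higher numbers stand for weaker inhibition and lower numbers for stronger inhibition), compound 3 gives 86.9 nM. Among the three compounds measured so far it stands second highest: compound 2 `O=c1cc(Cc2ccncc2)oc2cc(F)ccc12` gives 82.7 nM in this assay, which lies within the scatter of compound 3, while compound 1 `O=c1cc(Cc2ccncc2)oc2ccccc12` gives 223 nM, a higher number beyond the scatter. Within the data shown here, the only step recorded so far runs a 2.7-fold lower number from compound 1 to compound 2 (0.43 log units; beyond the scatter), a fluoro in place of hydrogen on an aromatic carbon. Compound 4 `O=c1c(Cc2cccnc2)coc2cc(F)ccc12` differs from compound 3 in another place: pyridin-3-yl in place of 1H-imidazol-1-yl on a saturated chain carbon bound to an aromatic carbon. Among the measured compounds shown here, no measured step exchanges one ring for another on the side chain, so the measured step from compound 1 to compound 2 does not bear on this change directly; compounds 1 and 2 do show that a pyridine ring on the side chain is compatible with inhibition in this assay. The step is therefore expected to be small, a 1.2-fold higher number from compound 3 to compound 4 (0.06 log units; within the scatter), in no firm direction. The estimate for compound 4 is 100 nM, expected to fall between 25 nM and 400 nM.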

Compound 4, half-maximal inhibitory concentration: > 10000 nM
Compound 4 ended at the assay's limit; the forecaster's own chance of this, stated with the estimate: 3%; middle value at least 100-fold (2.00 log units) away from the limit.
By their numbers in this assay, from the lowest: compounds 2 and 3 (each within the scatter of the next); then compound 1. At a limit, above all of these: compound 4.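

The ring on the side chain matters greatly at this position: pyridin-3-yl in place of 1H-imidazol-1-yl on a saturated chain carbon bound to an aromatic carbon gives an at least 110-fold higher number from compound 3 to compound 4 (2.06 log units; beyond the scatter). Compound 4 stands at a limit of the assay and not at a number, so the step gives only the smallest possible size of this loss of inhibition: the limit of > 10000 nM in this assay, at which 1 of the 4 values shown sits. Among these compounds, the one earlier step changed only a hydrogen to fluoro, whereas this exchange of one ring for another shows that inhibition in this assay can be lost almost entirely through the side chain alone.

This single pair changes ring size and the count of hetero atoms together, and it does not separate the two. On these data alone, whether a triazole ring or an open-chain amine on the same chain carbon would keep the inhibition seen with compound 3 also stays open.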